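Thiadiazole in place of pyrimidine on the sulfanyl arm

The source may hold more compounds than are shown below. What is called first, only, known or untested is meant among the compounds shown, and "the series" means these compounds.

Compound 1 `Cc1nnc(SCC(=O)N/N=c2/scc(-c3ccc(F)cc3)n2-c2ccccc2)s1` and compound 2 `Cc1nnc(SCC(=O)N/N=c2/scc(-c3ccc(Cl)cc3)n2-c2ccccc2)s1` differ only by chloro in place of fluoro on an aromatic carbon. In a functional assay on C6 cells (Rattus norvegicus) for cytotoxicity, read by MTT assay, with a stated time of 24 h, tested at 25 ug/mL (a lower number here means a stronger effect, a higher number a weaker effect of the compound at the concentration tested), compound 1 gives 50.1% and compound 2 gives 53.3%; the step of a number 3.2 percentage points higher from compound 1 to compound 2 (within the scatter) lies within the scatter. Compound 3 `Cc1ccc(-c2cs/c(=N/NC(=O)CSc3ncccn3)n2-c2ccccc2)cc1` differs from both in more than one place, and in this assay compound 3 gives 82.7%, the highest of the three numbers, beyond the scatter from compound 2 and from compound 1 alike.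

Compound 4 `Cc1ccc(-c2cs/c(=N/NC(=O)CSc3nnc(C)s3)n2-c2ccccc2)cc1` differs from compound 3 by 5-methyl-1,3,4-thiadiazol-2-yl in place of pyrimidin-2-yl on a sulfur. For the measured compounds named here, no measured step covers this exchange of the ring on the sulfur; the only measured step concerns the aromatic halogen and does not bear on it. Compound 4 shares its sulfanyl arm with compound 1 and compound 2, whose numbers sit well below that of compound 3, and the rest of its structure with compound 3, so a placement between the two groups is expected. The expected step is a number 20.7 percentage points lower from compound 3 to compound 4 (beyond the scatter), downward and beyond the scatter. In this assay compound 4 is thus estimated at 62%, with a range from 45% to 85%.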

Compound 4, a percentage reported as activity, at one concentration (the size of the read-out at that concentration, not a potency): 50.1%
Compound 4: the middle estimate sits 11.9 percentage points above what was measured; the range from low to high includes it.
By their numbers in this assay, from the lowest: compounds 1, 4 and 2 (each within the scatter of the next); then compound 3.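

On the sulfur bearing the saturated chain carbon, 5-methyl-1,3,4-thiadiazol-2-yl in place of pyrimidin-2-yl gives a number 32.6 percentage points lower from compound 3 to compound 4 (beyond the scatter) in this assay, so the ring on this sulfur has a large effect on the read-out in this pair. With the 5-methyl-1,3,4-thiadiazol-2-yl arm held constant, methyl in place of chloro gives a number 3.2 percentage points lower from compound 2 to compound 4 (within the scatter) and methyl in place of fluoro gives no change at the digits printed from compound 1 to compound 4 (within the scatter), so these three aromatic substituents are not told apart here. No available evidence bears on the reason for the ring exchange's effect.

On these data alone, it remains open whether the step keeps its size with chloro or fluoro in place of methyl on the aromatic carbon. Also open, as far as these compounds go, is how another ring on the sulfur, such as pyridin-2-yl or unmethylated 1,3,4-thiadiazol-2-yl, would read.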